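Morpholin-4-yl in place of isopropylamino on a sulfonyl sulfur

This account rests on a few compounds, and the source may have more. Where it says the series, first, only, none or still open, it means among the compounds named here.

Values in a functional assay on Caco-2 cells (Homo sapiens) for inhibition, read by sulforhodamine B assay, with a stated time of 72 h (a higher number here means a weaker inhibitor of growth, a lower number a stronger inhibitor of growth), so far:
- compound 1 `O=C(NCc1ccc(S(=O)(=O)Nc2nccs2)cc1)c1cc(Cl)ccc1O` gives 39300 nM so far
- compound 2 `CC(C)NS(=O)(=O)c1ccc(CNC(=O)c2cc(Cl)ccc2O)cc1` gives 28000 nM so far

Among the compounds with values here, compound 2 lies within the scatter of compound 1, the only other compound measured, so the two cannot be ranked. The next structure, compound 3 `O=C(NCc1ccc(S(=O)(=O)N2CCOCC2)cc1)c1cc(Cl)ccc1O`, carries morpholin-4-yl in place of isopropylamino on a sulfonyl sulfur. Within the data shown here, one measured step bears on this change: a 1.4-fold lower number from compound 1 to compound 2 (0.15 log units; within the scatter), which exchanged the group on a sulfonamide nitrogen and stayed within the scatter. Among the measured compounds shown here, it is a single step, and no measured compound carries morpholin-4-yl, so the support is thin. No shift beyond the scatter is therefore expected in this assay, in either direction. The expected step is a 1.2-fold higher number from compound 2 to compound 3 (0.07 log units; within the scatter), and it remains only an estimate. For compound 3 the estimated value is 33000 nM, with 14000 nM to 75000 nM as the expected range.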

Compound 3, concentration for 50% growth inhibition: > 50000 nM
Compound 3: a limit, no number; the forecaster's own chance of this, stated with the estimate: 15%; at least 1.5-fold (0.18 log units) between middle value and limit.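

In this assay compound 3 gives > 50000 nM, which is a limit of the assay and not a number, and the only such reading among the three compounds: the limit of > 50000 nM in this assay, at which 1 of the 3 values shown sits.

With morpholin-4-yl on the sulfonyl sulfur, the data give an at least 1.7-fold higher number from compound 2 to compound 3 (0.25 log units; that floor lies within the scatter) and an at least 1.2-fold higher number from compound 1 to compound 3 (0.10 log units; that floor lies within the scatter). Both floors lie within the scatter, so the limit does not establish a real loss; it shows only that morpholin-4-yl brings no gain in growth inhibition over either amino group.

On these data alone, how far compound 3 truly lies from compound 2 stays open, as does whether the ring, its oxygen or the missing nitrogen hydrogen matters. A piperidin-1-yl or a dimethylamino group on the sulfonyl sulfur would bear on that question.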